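The source may report more compounds than this note shows. Statements on the series, on what has been measured and on what is new or still open speak of the compounds shown alone.

In a functional assay on cells for agonist activity at Glucose-dependent insulinotropic receptor (Homo sapiens), read by a luciferase reporter, with a stated time of 6 h (a higher number here means that more compound is needed for the effect, a lower number that less compound is needed), compound 1 `CCc1cnc(N2CCC(c3nc(COc4ccc(/C=C5\CC(=O)NC5=O)cc4F)cs3)CC2)nc1` gives 49 nM. Among the compounds with values here, compound 2 `CC(C)(O)CN1CCC(c2nc(COc3c(F)cc(/C=C4\CC(=O)NC4=O)cc3F)cs2)CC1` gives "not determined" (no result reported) in this assay, so it stands nowhere on the scale and no step from it can be sized. Compound 3 `CCc1cnc(N2CCC(c3nc(COc4c(F)cc(/C=C5\CC(=O)NC5=O)cc4F)cs3)CC2)nc1` differs from compound 2 in one place: 5-ethylpyrimidin-2-yl in place of 2-hydroxy-2-methylpropyl on an amine nitrogen in a ring. Without a measured step, neither the direction nor the size of the change can be read off; the expectation below is a guess rather than an extrapolation. Compound 3 is expected to give about 45 nM, within a range from 15 nM to 150 nM. That guess leans on compound 1, which gives 49 nM.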

Compound 3, half-maximal effective concentration: 211 nM
Compound 3: middle estimate off by 4.7-fold (0.67 log units), on the low side; the whole stated range lies below it.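

In this assay, within the data shown here, fluoro in place of hydrogen on an aromatic carbon gives a 4.3-fold higher number from compound 1 to compound 3 (0.63 log units; beyond the scatter), the first step that can be sized here, and it runs towards more compound being needed. No measurement at hand accounts for this step. The step between compound 2 and compound 3 cannot be read, so 5-ethylpyrimidin-2-yl has no measured comparison with 2-hydroxy-2-methylpropyl on the amine nitrogen.

From the compounds shown here alone, it remains open whether a chloro or a methyl on that aromatic carbon would shift the number in the same way. Going by these compounds, it also remains open how an acetyl or a longer alkyl chain on the amine nitrogen would read.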